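The compounds below may be only part of what the source reports. "The series", "measured", "known", "first", "only" and "open" are said of these compounds alone.

Working notes on the series.

Of the compounds shown here, three have numbers so far. Compound 1 `O=C(CSc1nncnc1-c1cccc2ccccc12)Nc1ccccc1Br` gives 87000 nM in an ADME assay on MT4 cells (Homo sapiens) for cytotoxicity, read by MTT assay; a higher number here means that more compound is tolerated, a lower number that less compound is tolerated. Within the data shown here, compound 3 `Cc1ccccc1NC(=O)CSc1nncnc1-c1cccc2ccccc12` gives 158000 nM in this assay; the one step inside the set, a 1.8-fold higher number from compound 1 to compound 3 (0.26 log units; within the scatter), stays within the scatter. Compound 2 `O=C(CSc1nncnc1-c1ccccc1Cl)Nc1ccccn1` gives 172000 nM in this assay, the highest of the three numbers, though its gaps to compound 3 and to compound 1 both stay within the scatter, so no ordering among the three can be claimed.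

Compound 4 `O=C(CSc1nncnc1-c1ccccc1Cl)Nc1ccccc1Cl` has not yet been measured. It differs from compound 2 in one place: 2-chlorophenyl in place of pyridin-2-yl on an amide-type nitrogen. Among the measured compounds shown here, no measured step tracks this change directly; compound 1 and compound 3 carry an aryl amide on a different core, and their step is within the scatter, which is the only hint that swapping groups on the amide-type nitrogen leaves this assay largely unchanged. Compound 1, the nearest analogue carrying a halogen-bearing phenyl on that nitrogen, shows the lowest number of the three with 87000 nM, which leans the expectation slightly toward a lower number for compound 4, but not beyond the scatter.

For compound 4 the expected step is a 1.4-fold lower number from compound 2 to compound 4 (0.16 log units; within the scatter), within the scatter. Compound 4 is therefore estimated at 120000 nM, with a range from 50000 nM to 260000 nM.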

Compound 4, half-maximal cytotoxic concentration: 90000 nM
Compound 4: middle estimate off by 1.3-fold (0.12 log units), on the high side, and the stated range covers the measured number.
By their numbers in this assay, from the lowest: compounds 1, 4, 3 and 2 (each within the scatter of the next).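

In this assay, among these compounds, putting 2-chlorophenyl in place of pyridin-2-yl on an amide-type nitrogen gives a 1.9-fold lower number from compound 2 to compound 4 (0.28 log units; within the scatter), the first direct reading of a whole-ring exchange at this position, where the earlier compounds offered only a substituent exchange. Together with a 1.8-fold higher number from compound 1 to compound 3 (0.26 log units; within the scatter), there are now two single-place steps among these compounds, on two different cores, and neither goes beyond the scatter, so this read-out does not separate a pyridin-2-yl ring from a 2-chlorophenyl ring at this position. The compounds shown carry no information on what lies behind this result.

As far as these compounds go, it remains open whether a group of another kind on the amide-type nitrogen, such as a benzyl group, a cyclohexyl ring or a phenyl ring bearing a carboxylic acid or an amine, would give a step beyond the scatter. It is also open whether the same exchange of pyridin-2-yl for 2-chlorophenyl would read alike on the core of compound 1, since no pair shown tests it there.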